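From 4-methoxyphenyl to 2,4-dichlorophenyl on a shared core

A few compounds are considered here, and "the series" means these few. Any claim that something is new, unique, unknown or untested is made for them only; others in the source may bear on it.

Compound 1 `COc1ccc(OCCCON2C(N)=NC(N)=NC23CCOCC3)cc1`: 660 nM
Compound 2 `NC1=NC2(CCSCC2)N(OCCCOc2ccc(Br)cc2)C(N)=N1`: 740 nM
Compound 3 `NC1=NC2(CCSCC2)N(OCCCOc2cccc(Cl)c2Cl)C(N)=N1`: 1 nM

In a functional assay on A549 cells (Homo sapiens) for antiproliferative activity, read by MTT assay, with a stated time of 72 h (a higher number here means a weaker inhibitor, a lower number a stronger inhibitor), compound 1 gives 660 nM. That value lies within the usual scatter of compound 2 at 740 nM, so these two count as level. Compound 3 stands far lower, at 1 nM, which marks it as a much stronger inhibitor.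

Compound 4 `NC1=NC2(CCOCC2)N(OCCCOc2ccc(Cl)cc2Cl)C(N)=N1` has not been measured yet. It keeps the core of compound 1 and carries 2,4-dichlorophenyl in place of 4-methoxyphenyl on an oxygen on a saturated carbon.

Among the measured compounds shown here, one measured step bears on this change: a 740-fold lower number from compound 2 to compound 3 (2.87 log units; beyond the scatter), a large drop that came with 2,3-dichlorophenyl in place of 4-bromophenyl. It is only a loose guide. For the measured compounds named here, compound 2 and compound 3 share a core that differs from the core of compound 1, the dichlorophenyl group of compound 3 is not the one in compound 4, and the group that leaves is different too. A clear fall in the number is therefore expected, but a smaller one than that measured drop.

The expected change is a 22-fold lower number from compound 1 to compound 4 (1.34 log units; beyond the scatter). For compound 4 the estimate is 30 nM, with an expected range of 3 nM to 300 nM.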

Compound 4, half-maximal inhibitory concentration: 70 nM
The estimate for compound 4 lay 2.3-fold (0.37 log units) below the measured number; low and high end bracket the measured number.
By their numbers in this assay, from the lowest: compound 3; then compound 4; then compounds 1 and 2 (each within the scatter of the next).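

In this assay, placing 2,4-dichlorophenyl in place of 4-methoxyphenyl on an oxygen on a saturated carbon brings a 9.4-fold lower number from compound 1 to compound 4 (0.97 log units; beyond the scatter) on the core that carries this change, so the swap is a real gain here and not just scatter. Among the compounds shown here, the only earlier step at this place was measured on a different core with other groups entering and leaving, so it could not show whether a dichlorophenyl group would lower the number on this core as well. This step is modest where the earlier one was large, but the two differ in core, in the group that leaves and in the group that enters, so the gap in size cannot be assigned to any one of these, and no measurement at hand explains either step.

From the compounds shown here alone, what remains open is how much each chlorine contributes, which 4-chlorophenyl or unsubstituted phenyl at the same place would help to show. Going by these compounds, it is also open whether the arrangement of the chlorines or the core matters more, a question that 2,3-dichlorophenyl on this core could address.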